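A few compounds are considered here, and "the series" means these few. Any claim that something is new, unique, unknown or untested is made for them only; others in the source may bear on it.

Measured in a functional assay on MCF7 cells (Homo sapiens) for antiproliferative activity, read by MTT assay, with a stated time of 48 h (on this read-out higher numbers stand for weaker inhibition and lower numbers for stronger inhibition), so far:
- compound 1 `O=C(/C=C/c1ccc2c(c1)OCCO2)NS(=O)(=O)c1ccc(F)cc1` gives 52.1 ug/mL
- compound 2 `O=C(/C=C/c1ccc2c(c1)OCCO2)NS(=O)(=O)c1ccc(Cl)cc1` gives 51.3 ug/mL

Compound 2 at 51.3 ug/mL sits level with compound 1 at 52.1 ug/mL within the scatter, so neither stands apart on these numbers. Next in the series is compound 3 `O=C(/C=C/c1ccc2c(c1)OCCO2)NS(=O)(=O)c1ccc(Br)cc1` with bromo in place of chloro on an aromatic carbon, para to a large group (bromo in place of chloro on an aromatic carbon). For the measured compounds named here, the only measured step bearing on this is chloro in place of fluoro on an aromatic carbon, a 1.0-fold lower number from compound 1 to compound 2 (0.01 log units; within the scatter) and that step stays within the scatter. Going by the values given here, with only that step as a guide, no change beyond the scatter is expected in this assay for this exchange. The expected move is a 1.0-fold lower number from compound 2 to compound 3 (0.01 log units; within the scatter) and so stays within the scatter. Compound 3 is estimated at 50 ug/mL with an expected range from 32 ug/mL to 75 ug/mL in this read-out.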

Compound 3, half-maximal inhibitory concentration: > 100 ug/mL
Compound 3 was reported as a limit; the forecaster's own chance of this, stated with the estimate: 3%; at least 2.0-fold (0.30 log units) between middle value and limit.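

In this assay compound 3 gives > 100 ug/mL, which is a limit and not a number. Bromo in place of chloro on an aromatic carbon gives an at least 1.9-fold higher number from compound 2 to compound 3 (0.28 log units; that floor lies within the scatter), and bromo in place of fluoro gives an at least 1.9-fold higher number from compound 1 to compound 3 (0.28 log units; that floor lies within the scatter). Compounds 1 and 2 alone left this place, para to a large group, looking indifferent to the halogen; compound 3 no longer supports that reading, yet its floors do not establish a change beyond the scatter.

Going by these compounds, the true size of the bromo steps stays open, with the comparison resting on one value that is only a limit: the limit of > 100 ug/mL in this assay, at which 1 of the 3 values shown sits. Whether a methoxy or an amine at the same place would read with the fluoro and chloro compounds or with the bromo compound also stays open.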